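Inverting the chain stereocentre of compound 2

The source may hold more compounds than are shown below. What is called first, only, known or untested is meant among the compounds shown, and "the series" means these compounds.

In an assay for binding affinity, read by spectrophotometry (on this read-out higher numbers stand for weaker inhibition and lower numbers for stronger inhibition), compound 1 (`C[C@@H](CCCNC(C)(C)C)Nc1ccnc2cc(Cl)ccc12`) gives 150000 nM and compound 2 (`CCCCCCCCN(CCCCCCCC)CCC[C@H](C)Nc1ccnc2cc(Cl)ccc12`) gives 200000 nM on the same read-out, two values that lie within the scatter of each other. Going to compound 3 (`CCCCCCCCN(CCCCCCCC)CCC[C@@H](C)Nc1ccnc2cc(Cl)ccc12`) brings the two compounds have the same atoms and bonds and differ only in configuration as drawn: 1 of 1 stereo elements differ; a stereocentre at a saturated chain carbon is drawn S in compound 2 and R in compound 3 as the only change: the same atoms and bonds, with a stereocentre at a saturated chain carbon drawn S in compound 2 and R in compound 3. Among the measured compounds shown here, no two measured compounds differ in one place, so the series offers no measured step to size this change against. The expectation therefore starts from compound 2 at 200000 nM as its anchor, and no step beyond the scatter is expected in this assay, with neither direction favoured. The estimated move no change at the digits printed from compound 2 to compound 3 (within the scatter) stays small on this reading. For compound 3 the estimated value in this assay is 200000 nM with an expected range from 100000 nM to 400000 nM around it.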

Compound 3, half-maximal inhibitory concentration: 190000 nM
Compound 3: middle estimate off by 1.1-fold (0.02 log units), on the high side; the range from low to high includes it.
By their numbers in this assay, from the lowest: compounds 1, 3 and 2 (each within the scatter of the next).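

Among the compounds shown here, compounds 1 and 2 offered no pair differing in one place, so the stereocentre at the saturated chain carbon could not be sized until now. In this assay, inverting it gives a 1.1-fold lower number from compound 2 to compound 3 (0.02 log units; within the scatter), so the drawn configuration at this position does not separate the two compounds on this read-out, with the octyl chains on the amine held constant. The pair gives a direct reading of the stereocentre alone, with nothing else to account for: the fact that compounds 2 and 3 differ only in the configuration as drawn

From the compounds shown here alone, whether the configuration counts for as little with a diethylamino group or a carboxylic acid in place of the dioctylamino group stays open. This is a single pair in a single assay, so it cannot say whether the same holds for the S and R forms of any other member of the series, including the partner of compound 1 at this stereocentre.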